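Chain length and ring size in a small cytotoxicity series

A few compounds are considered here, and "the series" means these few. Any claim that something is new, unique, unknown or untested is made for them only; others in the source may bear on it.

Measured compounds:
compound 1, `CCCOP(=O)(O)OCCSC(=S)N1CCCC1`, gives 67000 nM in a functional assay on MDA-MB-231 cells (Homo sapiens) for inhibition, read by MTT assay, with stated times of 18 h and 4 h; a lower number here means a stronger inhibitor, a higher number a weaker inhibitor
compound 2, `CCCCCCOP(=O)(O)OCCSC(=S)N1CCCCCC1`, gives 17200 nM in this assay
compound 3, `CCCCCCOP(=O)(O)OCCSC(=S)N1CCCC1`, gives 54000 nM in this assay

Compound 2 has the lowest number of the three, and its steps to both others lie beyond the scatter. The cores of compound 2 and compound 3 differ by azepan-1-yl in place of pyrrolidin-1-yl on a thiocarbonyl carbon; the step is a 3.1-fold higher number from compound 2 to compound 3 (0.50 log units; beyond the scatter). The other change, (hydrogen in place of propyl on a saturated chain carbon, three bonds along the chain from an oxygen on an unsaturated carbon), gives a 1.2-fold higher number from compound 3 to compound 1 (0.09 log units; within the scatter), so on the pyrrolidin-1-yl core shortening the chain hardly registers.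

Compound 4, `CCCOP(=O)(O)OCCSC(=S)N1CCCCCC1`, is not yet measured. It differs from compound 2 by hydrogen in place of propyl on a saturated chain carbon, three bonds along the chain from an oxygen on an unsaturated carbon, the same change as from compound 3 to compound 1, at the same place. Within the data shown here, the step from compound 2 to compound 4 is therefore expected to be small, about a 1.2-fold higher number from compound 2 to compound 4 (0.07 log units; within the scatter), because a 1.2-fold higher number from compound 3 to compound 1 (0.09 log units; within the scatter) stayed within the scatter; with only one precedent the range is kept wide. Compound 4 is estimated at 20000 nM, expected between 10000 nM and 40000 nM.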

Compound 4, half-maximal inhibitory concentration: 38000 nM
Compound 4: middle estimate off by 1.9-fold (0.28 log units), on the low side; the range from low to high includes it.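

In this assay, shortening hexyl to propyl on the core of compound 2 gives a 2.2-fold higher number from compound 2 to compound 4 (0.34 log units; beyond the scatter), so on this core the change registers as a modest loss, whereas on the core of compound 3 it stayed within the scatter. Read side by side, the two steps cannot be told apart, and the change carries across these two cores as far as the data can show: the same change on two cores in this assay, a 1.2-fold higher number (0.09 log units; within the scatter) from compound 3 to compound 1 and a 2.2-fold higher number (0.34 log units; beyond the scatter) from compound 2 to compound 4, 1.8-fold (0.25 log units) apart, within the scatter of two such steps. This does not show that the size of the step is the same on both cores, since one pair alone lies beyond the scatter and two pairs are a thin base, nor does it give any rule for a core outside this series.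

Still open, going by these compounds, is how chains other than propyl and hexyl behave, such as butyl or a longer chain like decyl. Also open, on these data alone, is whether piperidin-1-yl on the thiocarbonyl carbon would fall in line with the pyrrolidin-1-yl and azepan-1-yl compounds.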